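The source may report more compounds than this note shows. Statements on the series, on what has been measured and on what is new or still open speak of the compounds shown alone.

Measured so far in a physicochemical assay for lipophilicity, read by HPLC, in phosphate buffer, measured as octanol-water partition, at pH 7.4, tested at 100 uM; a higher number here means a more lipophilic compound, a lower number a more polar compound:
- compound 1 `O=C(O)COc1ccc(NCc2cccc(-c3ccccc3)c2)cc1F`: 2.25
- compound 2 `COc1ccccc1-c1cccc(CNc2ccc(OCC(=O)O)c(F)c2)c1`: "not determined" (no result reported)

Compound 2 has no number to stand on, since its entry reads "not determined" (no result reported) and no result was reported. The only measured reference nearby is compound 1, at 2.25.

The next molecule is compound 3 `Cc1ccc(-c2cccc(CNc3ccc(OCC(=O)O)c(F)c3)c2)c(Cl)c1`. It keeps the shared core and swaps one group on an aromatic carbon, meta to a large group, (2-chloro-4-methylphenyl in place of 2-methoxyphenyl on an aromatic carbon). In words, 2-chloro-4-methylphenyl takes the place of 2-methoxyphenyl.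

Among the compounds with values here, no measured pair shows what this swap does, so the step cannot be read from the data. In this assay, a moderate upward step beyond the usual scatter is expected, judged against compound 1 at 2.25. For compound 3 the estimated value is 2.9, with an expected range from 2.4 to 3.4.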

Compound 3, distribution coefficient: 3.24
For compound 3 the middle estimate is 0.34 log units below the measured one; low and high end bracket the measured number.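

In this assay, putting 2-chloro-4-methylphenyl in place of phenyl on an aromatic carbon, meta to a large group, gives a number 0.99 log units higher from compound 1 to compound 3 (beyond the scatter). Within the data shown here, this is the first measured sign that the number responds to a change at this position, and the step is large enough to stand clear of ordinary repeat variation. Compound 2 has no reported result, so the step from it to compound 3 cannot be read, and the data offer no measured explanation for the rise.

As far as these compounds go, compound 3 adds the chlorine and the methyl together, so the share of the step belonging to each remains open. Also open, from the compounds shown here alone, is how the number would respond to a phenyl carrying an amine or a carboxylic acid at this position.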